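The source may report more compounds than this note shows. Statements on the series, on what has been measured and on what is new or still open speak of the compounds shown alone.

Compound 1 `O=C(O)c1ccc(NC(=O)c2ccc(-c3nn[nH]n3)cc2)cc1`: 3.5 mg/kg
Compound 2 `NC(=O)c1ccc(NC(=O)c2ccc(-c3nn[nH]n3)cc2)cc1`: 33 mg/kg
Compound 3 `N#Cc1ccc(C(=O)Nc2cc(C(N)=O)cc(C(=O)O)c2)cc1`: 87.2 mg/kg

All three were tested in a functional assay on the whole organism (stomach) with Rattus norvegicus as the target; on this read-out higher numbers stand for an effect only at larger amounts of compound and lower numbers for an effect already at smaller amounts. Compound 1 and compound 2 share one core and differ in a single change, (hydroxy in place of amino on a carbonyl carbon), which gave a 9.4-fold lower number from compound 2 to compound 1 (0.97 log units; beyond the scatter). Compound 3 sits on a second core, and the difference between the two cores is not broken down here. In this assay compound 3 gives the highest of the three numbers. Compound 4 `N#Cc1ccc(C(=O)Nc2cc(C(=O)O)cc(C(=O)O)c2)cc1` is not yet measured; it arises from compound 3 by hydroxy in place of amino on a carbonyl carbon, the same change as from compound 2 to compound 1, on an identical place. A step of the same direction is expected for compound 4, namely a 5.8-fold lower number from compound 3 to compound 4 (0.76 log units; beyond the scatter), because the same change earlier gave a 9.4-fold lower number from compound 2 to compound 1 (0.97 log units; beyond the scatter). The core differs, so a somewhat smaller step is allowed for. The estimate for compound 4 is 15 mg/kg, most likely between 4 mg/kg and 50 mg/kg.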

Compound 4, dose for 50% inhibition: 32.1 mg/kg
Estimate against measurement, compound 4: 2.1-fold (0.33 log units) below; the measured number falls inside the stated range.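

Carboxy in place of carbamoyl again gives a lower number in this assay, here a 2.7-fold lower number from compound 3 to compound 4 (0.43 log units; beyond the scatter) and so in the same direction as on the core of compound 1. Going by these compounds alone, with only two pairs, this shows that the direction held on both cores, not that it would hold on any further core, and it does not explain why the size of the step changed. The size itself did not carry over unchanged: the same change on two cores in this assay, a 9.4-fold lower number (0.97 log units; beyond the scatter) from compound 2 to compound 1 and a 2.7-fold lower number (0.43 log units; beyond the scatter) from compound 3 to compound 4, 3.5-fold (0.54 log units) apart, beyond the scatter of two such steps

Which part of the two cores sets the size of the step remains open. So does whether a methyl ester or a sulfonic acid in place of the carboxy would shift the number in the same way.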